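This account rests on a few compounds, and the source may have more. Where it says the series, first, only, none or still open, it means among the compounds named here.

Measured in a functional assay on PC-3 cells (Homo sapiens) for antiproliferative activity, read by MTT assay, with a stated time of 72 h; on this read-out higher numbers stand for weaker inhibition and lower numbers for stronger inhibition:
- Compound 1 `CCCCCCCCCCCCNC[C@@H]1OC[C@H](N)[C@H]1O`: 2380 nM
- Compound 2 `CCCCCCCCCCCCCCNC[C@@H]1OC[C@H](N)[C@H]1O`: 1990 nM
- Compound 3 `CCCCCCCCCCCNC[C@@H]1OC[C@H](N)[C@H]1O`: 10000 nM

Compound 3 has the highest number of the three, making it the weakest inhibitor so far. Compound 4 `CCCCCCCCCCNC[C@@H]1OC[C@H](N)[C@H]1O` is not yet measured and differs from compound 3 by one change: hydrogen in place of methyl on a saturated chain carbon, ten or more bonds along the chain from an amine nitrogen. The same swap gave a 4.2-fold higher number from compound 1 to compound 3 (0.62 log units; beyond the scatter), a modest loss of inhibition. Removing more of the chain gave a 5.0-fold higher number from compound 2 to compound 3 (0.70 log units; beyond the scatter), also modest, whereas a 1.2-fold lower number from compound 1 to compound 2 (0.08 log units; within the scatter) stayed within the scatter. With only these steps to go on, another modest rise is expected in this assay, meaning weaker inhibition. The expected step is a 2.2-fold higher number from compound 3 to compound 4 (0.34 log units; beyond the scatter). The estimate for compound 4 is 22000 nM, with an expected range of 10000 nM to 50000 nM.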

Compound 4, half-maximal inhibitory concentration: > 128000 nM
Compound 4: no number, only a limit; the forecaster's own chance of this, stated with the estimate: 30%; middle value at least 5.8-fold (0.76 log units) away from the limit.
By their numbers in this assay, from the lowest: compounds 2 and 1 (each within the scatter of the next); then compound 3. At a limit, above all of these: compound 4.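

In this assay, compound 4 gives no number, only a limit: the limit of > 128000 nM in this assay, at which 1 of the 4 values shown sits.

Removing this one methyl gives an at least 12-fold higher number from compound 3 to compound 4 (1.10 log units; beyond the scatter), a far larger step than the same change on a longer chain, a 4.2-fold higher number from compound 1 to compound 3 (0.62 log units; beyond the scatter), so equal trims of the chain do not cost equal amounts of inhibition. Measured from the two longest chains, the loss is also large: an at least 53-fold higher number from compound 1 to compound 4 (1.73 log units; beyond the scatter) and an at least 64-fold higher number from compound 2 to compound 4 (1.80 log units; beyond the scatter).

From the compounds shown here alone, it remains open whether a longer chain would lower the number further than in compound 2. Also open, going by these compounds, is how a chain carrying a phenyl ring or an ether oxygen would behave in this assay.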